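The compounds below may be only part of what the source reports. "The series", "measured", "known", "first", "only" and "open" are said of these compounds alone.

Among the compounds with values here, in a functional assay on HepG2 cells (Homo sapiens) for inhibition, read by MTT assay (on this read-out lower numbers stand for stronger inhibition of growth and higher numbers for weaker inhibition of growth), compound 1 `COc1cc2oc(-c3cccc(NC(=O)c4ccccc4)c3)cc(=O)c2c(OC)c1OC` gives 11700 nM, while compound 2 `COc1cc2oc(-c3cccc(NC(=O)c4ccc(F)cc4)c3)cc(=O)c2c(OC)c1OC` gives 47200 nM, the higher of the two numbers measured so far. Compound 3 `COc1cc2oc(-c3cccc(NC(=O)c4cccc(C#N)c4)c3)cc(=O)c2c(OC)c1OC` has yet to be measured. Its difference from compound 2 is 3-cyanophenyl in place of 4-fluorophenyl on a carbonyl carbon; in short, 3-cyanophenyl in place of 4-fluorophenyl on a carbonyl carbon. Within the data shown here, one measured step bears on this change: a 4.0-fold higher number from compound 1 to compound 2 (0.61 log units; beyond the scatter), modest and beyond the scatter, for fluoro in place of hydrogen on an aromatic carbon. Among the measured compounds shown here, no measured compound carries the 3-cyanophenyl group, so the data say nothing direct about it. With compound 2 at 47200 nM and compound 1 at 11700 nM, a modest move to a lower number is expected in this assay, though with wide uncertainty. The expected step is a 1.9-fold lower number from compound 2 to compound 3 (0.28 log units; within the scatter). The estimate for compound 3 is 25000 nM, with an expected range of 9000 nM to 70000 nM.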

Compound 3, concentration for 50% growth inhibition: 11900 nM
Estimate against measurement, compound 3: 2.1-fold (0.32 log units) above; the range from low to high includes it.
By their numbers in this assay, from the lowest: compounds 1 and 3 (each within the scatter of the next); then compound 2.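

In this assay, 3-cyanophenyl in place of 4-fluorophenyl on the carbonyl carbon gives a 4.0-fold lower number from compound 2 to compound 3 (0.60 log units; beyond the scatter), so the higher number of compound 2 does not extend to both substituted rings shown. Cyano in place of hydrogen gives a 1.0-fold higher number from compound 1 to compound 3 (0.01 log units; within the scatter), which is within the scatter, leaving only the 4-fluorophenyl compound apart from compound 1 among these three. Nothing in the data offers a reason for this difference between the two groups.

Compound 2 and compound 3 differ in both the group and its place on the ring, so the compounds shown cannot separate these two changes; 3-fluorophenyl and 4-cyanophenyl would bear directly on that question. From the compounds shown here alone, how an amine or a carboxylic acid on this ring would read in this assay also remains open.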